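This account rests on a few compounds, and the source may have more. Where it says the series, first, only, none or still open, it means among the compounds named here.

Measured compounds in a physicochemical assay for solubility, with a stated time of 18 h, at pH 7.4; on this read-out higher numbers stand for higher solubility and lower numbers for lower solubility:
compound 1 `COc1ccc(Oc2ccc3c(NCCCNCc4cc(F)ccc4OC)ccnc3c2)cc1`, 14500 nM
compound 2 `CC(C)(C)c1ccc(-c2ccc3c(NCCCNCc4ccco4)ccnc3c2)cc1`, 32000 nM
compound 3 `COc1ccc(Oc2ccc3c(NCCCNCc4cccc(OC)c4O)ccnc3c2)cc1`, 14500 nM

On these numbers compound 1 stands level with compound 3, the two together the lowest of the three, while compound 2 gives a number higher than that of compound 1 by a margin beyond the scatter. Among the measured compounds shown here, the only single-point step among the measured compounds, no change at the digits printed from compound 1 to compound 3 (within the scatter), showed no change beyond the scatter. The unmeasured compound 4 `COc1ccc(F)cc1CNCCCNc1ccnc2cc(Oc3ccc(C(C)(C)C)cc3)ccc12` differs from compound 1 in one place: tert-butyl in place of methoxy on an aromatic carbon. For the measured compounds named here, no measured step covers this change. Going by the values given here, compound 2 also carries a tert-butyl group, but it differs from compound 1 in more than one place, so its value shows only that a compound bearing tert-butyl can reach a higher number in this assay. The expectation for this step therefore rests on thin ground, and the step expected is a 2.1-fold lower number from compound 1 to compound 4 (0.32 log units; beyond the scatter). The value expected for compound 4 is 7000 nM, within a range from 2000 nM to 25000 nM.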

Compound 4, solubility: 14500 nM
Estimate against measurement, compound 4: 2.1-fold (0.32 log units) below; low and high end bracket the measured number.
By their numbers in this assay, from the lowest: compounds 1, 3 and 4 (each within the scatter of the next); then compound 2.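

In this assay the result is no change at the digits printed from compound 1 to compound 4 (within the scatter) with 4-(tert-butyl)phenoxy in place of 4-methoxyphenoxy, so at this aromatic carbon, para to a large group, tert-butyl and methoxy give numbers that cannot be told apart. Among the compounds shown here, the only earlier single-place step, no change at the digits printed from compound 1 to compound 3 (within the scatter) on swapping the aromatic group on the saturated chain carbon bound to an amine nitrogen, gave no reading at this place, and this one extends the no-change outcome to a second part of the molecule. Nothing available here bears on why the number holds.

Going by these compounds, whether this place would hold the number with an amine, a carboxylic acid or a longer ether chain in place of methoxy remains open. Also open, on these data alone, is whether the same change would read alike on a different amine side chain.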